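Alkyl-to-Benzyl Switch on the Chain Nitrogen Substituent

This account rests on a few compounds, and the source may have more. Where it says the series, first, only, none or still open, it means among the compounds named here.

Compound 1, `CCn1c(SCc2ccccc2)nnc1-c1cc([N+](=O)[O-])cc([N+](=O)[O-])c1`: in an ADME assay on A-431 cells (Homo sapiens) for cytotoxicity, with a stated time of 48 h (on this read-out higher numbers stand for weaker inhibition and lower numbers for stronger inhibition), compound 1 gives > 30000 nM, which is a limit of the assay and not a number.
Compound 2, `CCCCCCn1c(SCc2ccccc2)nnc1-c1cc([N+](=O)[O-])cc([N+](=O)[O-])c1`: in this assay compound 2 gives > 30000 nM, again a limit of the assay.

Compound 2 therefore stands at the assay limit, with no number of its own. The step that the two limits leave unreadable from compound 1 to compound 2 is unreadable because the limit of > 30000 nM in this assay, at which 2 of the 2 values shown sit, holds both values shown. Compound 3, `O=[N+]([O-])c1cc(-c2nnc(SCc3ccccc3)n2Cc2ccccc2)cc([N+](=O)[O-])c1`, differs from compound 2 by phenyl in place of pentyl on a saturated chain carbon bound to an aromatic nitrogen. Among the measured compounds shown here, no measured step speaks to this change, since the only step available is itself hidden by the limit. With both neighbours at the limit, compound 3 is expected to sit there as well. For compound 3 the estimate is 40000 nM, with a range from 12000 nM to 120000 nM. The expected step is a step that the limit leaves unreadable from compound 2 to compound 3, which is none beyond the scatter.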

Compound 3, half-maximal inhibitory concentration: > 30000 nM
Compound 3 gave a limit, no number; the forecaster's own chance of this, stated with the estimate: 70%; the middle value is on the limit's open side.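

No step among compound 1, compound 2 and compound 3 can be read in this assay, because all three values are limits of the assay and not numbers: the limit of > 30000 nM in this assay, at which 3 of the 3 values shown sit.

The compounds shown leave open whether the change from hexyl to benzyl, or any other change at this substituent, alters cytotoxicity in this assay.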